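Butoxycarbonyl in place of dimethylsulfamoyl on a biaryl

The source may hold more compounds than are shown below. What is called first, only, known or untested is meant among the compounds shown, and "the series" means these compounds.

Measured compounds:
compound 1 `CCOC(=O)c1cccc(-c2ccc3[nH]ccc3c2)c1` with 60000 nM
compound 2 `CCOc1ccc(-c2cccc(S(=O)(=O)N(C)C)c2)cc1` with 110000 nM

In an assay on COS-7 cells for inhibition of patatin-like phospholipase domain-containing protein 2 (Mus musculus) (a lower number here means a stronger inhibitor, a higher number a weaker inhibitor), compound 1 gives 60000 nM. In this assay compound 2 gives 110000 nM, the highest of the two numbers shown, and the gap between compound 2 and compound 1 lies within the usual scatter of repeated measurements, so the two values say the same thing: both compounds are weak inhibitors.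

Compound 3 `CCCCOC(=O)c1cccc(-c2ccc(OCC)cc2)c1` has not yet been measured in this assay. It differs from compound 2 in one place: butoxycarbonyl in place of dimethylsulfamoyl on an aromatic carbon. Among the measured compounds shown here, no step between measured compounds matches this change, so there is nothing to lean on beyond the fact that compound 1, which also carries an ester-type group on a six-membered aromatic ring, sits at 60000 nM. The step from compound 2 to compound 3 is therefore expected to be small, a 1.5-fold lower number from compound 2 to compound 3 (0.17 log units; within the scatter), and most likely not beyond the scatter in either direction. For compound 3 the estimate is 75000 nM, with a range from 25000 nM to 220000 nM.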

Compound 3, half-maximal inhibitory concentration: 100000 nM
Beside the measured number, compound 3's estimate is 1.3-fold (0.12 log units) below it, and the stated range covers the measured number.
By their numbers in this assay, from the lowest: compounds 1, 3 and 2 (each within the scatter of the next).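

In this assay the exchange of dimethylsulfamoyl for butoxycarbonyl on an aromatic carbon of the six-membered ring gives a 1.1-fold lower number from compound 2 to compound 3 (0.04 log units; within the scatter) and so leaves compound 2 and compound 3 indistinguishable, which shows that at this position the two groups can stand in for each other without a readable difference in the number. The exchange is not a close one on paper: 6 heavy atoms with sulfur and nitrogen leave, and 7 heavy atoms of carbon and oxygen enter, with 2 double bonds outside aromatic rings becoming 1, while both groups hold 2 hydrogen-bond acceptors and 0 hydrogen-bond donors. No supporting measurement bears on why the two groups read alike.

As far as these compounds go, whether any group at this position can move the number beyond the scatter remains open, for instance a carboxylic acid, an amine or a primary amide in place of the butyl ester. Also open, from the compounds shown here alone, is whether a longer chain or a hydroxyl in place of the ethoxy group of the shared core would do so.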